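Benzyl Substituent Swap in the Cytotoxicity Series

The source may hold more compounds than are shown below. What is called first, only, known or untested is meant among the compounds shown, and "the series" means these compounds.

Compound 1 `N#Cc1ccc(Cn2cc(COc3ccc4c(=O)ccoc4c3)nn2)cc1` is tested in an ADME assay on L02 cells (Homo sapiens) for cytotoxicity, read by MTT assay, with a stated time of 48 h; a higher number here means a weaker inhibitor, a lower number a stronger inhibitor. For compound 1 the result is a limit of the assay, > 300000 nM. Compound 2 `O=c1ccoc2cc(OCc3cn(Cc4cccc(F)c4)nn3)ccc12` likewise returns a limit, > 300000 nM. Compound 3 `O=c1ccoc2cc(OCc3cn(Cc4ccccc4Br)nn3)ccc12` also stands at a limit, > 300000 nM. The steps a step that the two limits leave unreadable from compound 1 to compound 2, a step that the two limits leave unreadable from compound 1 to compound 3 and a step that the two limits leave unreadable from compound 2 to compound 3 are therefore unreadable; all three values share (the limit of > 300000 nM in this assay, at which 3 of the 3 values shown sit). Compound 4 `O=c1ccoc2cc(OCc3cn(Cc4ccc(F)cc4)nn3)ccc12` differs from compound 1 by fluoro in place of cyano on an aromatic carbon. The steps from compound 1 to compound 2 and to compound 3 bear on this change most closely, yet neither gives a size. No step beyond the scatter is therefore expected in this assay, and compound 4 is expected to remain at the same limit, a number no higher from compound 1 to compound 4 (the limit leaves the size open). The estimate for compound 4 is 300000 nM, between 150000 nM and 600000 nM.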

Compound 4, half-maximal inhibitory concentration: > 300000 nM
Compound 4: no number, only a limit; the forecaster's own chance of this, stated with the estimate: 85%; the middle value sits exactly at the limit.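

Compound 4 gives > 300000 nM as a limit, so no step linking it to compound 1, compound 2 or compound 3 can be read: the limit of > 300000 nM in this assay, at which 4 of the 4 values shown sit.

In this assay the compounds shown leave open whether any of these benzyl substituent swaps changes the result.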